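Working notes: from compound 3 to compound 4

A few compounds are considered here, and "the series" means these few. Any claim that something is new, unique, unknown or untested is made for them only; others in the source may bear on it.

Values so far in a functional assay on DU-145 cells (Homo sapiens) for cytotoxicity, read by trypan blue exclusion, with a stated time of 96 h (a higher number here means a weaker inhibitor, a lower number a stronger inhibitor), for the series:
- compound 1 `COc1cc(OC)c(/C=C/S(=O)(=O)Cc2ccc(OC)c([N+](=O)[O-])c2)c(OC)c1` gives 2500 nM
- compound 2 `COc1cc(OC)c(/C=C/S(=O)(=O)Cc2ccc(OC)c(N)c2)c(OC)c1` gives 4 nM
- compound 3 `COC(=O)C(Nc1cc(CS(=O)(=O)/C=C/c2c(OC)cc(OC)cc2OC)ccc1OC)c1ccc(Br)cc1` gives 300 nM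

Compound 3 stands second highest of the three numbers and lies closer to compound 1 than to compound 2. Compound 4 `COc1cc(OC)c(/C=C/S(=O)(=O)Cc2ccc(OC)c(NC(C)(C)C(=O)O)c2)c(OC)c1` differs from it by 1-carboxy-1-methylethyl in place of (4-bromophenyl)(methoxycarbonyl)methyl on a nitrogen on an aromatic ring and so has 1-carboxy-1-methylethyl in place of (4-bromophenyl)(methoxycarbonyl)methyl on a nitrogen on an aromatic ring. The most direct evidence is the large 75-fold higher number from compound 2 to compound 3 (1.88 log units; beyond the scatter) on that same nitrogen. The large 630-fold lower number from compound 1 to compound 2 (2.80 log units; beyond the scatter) bears only on the amino group itself. Among the measured compounds shown here, no measured compound carries 1-carboxy-1-methylethyl, so only part of the first of these steps is expected to be regained. The expected move is a 5.0-fold lower number from compound 3 to compound 4 (0.70 log units; beyond the scatter) in this assay toward a lower number. Compound 4 is estimated at 60 nM with a range from 10 nM to 400 nM expected.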

Compound 4, half-maximal inhibitory concentration: 150 nM
For compound 4 the middle estimate is 2.5-fold (0.40 log units) below the measured one, within the range that was stated.
By their numbers in this assay, from the lowest: compound 2; then compounds 4 and 3 (each within the scatter of the next); then compound 1.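

In this assay, a much smaller, ringless group on the nitrogen on an aromatic ring still gives a large loss against the free amine (a 38-fold higher number from compound 2 to compound 4 (1.57 log units; beyond the scatter)). Exchanging the two substituents makes no difference beyond the scatter (a 2.0-fold lower number from compound 3 to compound 4 (0.30 log units; within the scatter)), so the loss does not depend on the bromophenyl ring or the ester in this pair. The substituted amine still keeps a large gain over the nitro group (a 17-fold lower number from compound 1 to compound 4 (1.22 log units; beyond the scatter)). No measurement shown gives a cause for these shifts. Open, going by these compounds, is whether a plain methyl or an acetyl on this nitrogen would stay near compound 2 or fall with compound 3 and compound 4.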